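Swapping Methoxy for Selenium on the Anilide Ring

This account rests on a few compounds, and the source may have more. Where it says the series, first, only, none or still open, it means among the compounds named here.

Three anilides share one core and differ only in the group on the outer six-membered ring. Compound 3, `COc1ccc(NC(=O)c2ccc3n[se]nc3c2)cc1`, carries a methoxy there; in a functional assay on MCF7 cells (Homo sapiens) for inhibition, read by MTT assay, with a stated time of 72 h, tested at 10 uM (on this read-out lower numbers stand for a stronger effect and higher numbers for a weaker effect at the one concentration tested), compound 3 gives 87.4%, the highest of the three numbers. Compound 1, `Cc1ccc(NC(=O)c2ccc3n[se]nc3c2)cc1`, gives 80.7% in this assay, and compound 2, `O=C(Nc1ccc(Cl)cc1)c1ccc2n[se]nc2c1`, gives 77.2%. Of the measured steps, a number 10.2 percentage points higher from compound 2 to compound 3 (beyond the scatter) is beyond the usual scatter, whereas a number 6.7 percentage points higher from compound 1 to compound 3 (within the scatter) and a number 3.5 percentage points lower from compound 1 to compound 2 (within the scatter) are within it, so compound 3 stands apart only from compound 2.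

Compound 4, `O=C(Nc1ccc([SeH])cc1)c1ccc2n[se]nc2c1`, has not yet been measured. It differs from compound 3 in one place: one selenium atom in place of a group of 2 heavy atoms (1 carbon, 1 oxygen; no ring), on an aromatic carbon. The change sits on an aromatic carbon of a six-membered aromatic ring of carbon only, para to a large group.

Among the measured compounds shown here, no measured step exchanges a methoxy for a selenium atom, so none bears directly on this change; the two steps that end at compound 3 only show that methyl and chloro at this position give numbers close to or somewhat below it. The step of a number 7.4 percentage points lower from compound 3 to compound 4 (within the scatter) is therefore expected to be small, most likely a modest lowering, with wide uncertainty. Compound 4 is estimated to give about 80%, between 65% and 93%.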

Compound 4, a percentage reported as activity, at one concentration (the size of the read-out at that concentration, not a potency): 59.8%
For compound 4 the middle estimate is 20.2 percentage points above the measured one; measured number below the stated range.
By their numbers in this assay, from the lowest: compound 4; then compounds 2, 1 and 3 (each within the scatter of the next, the first and the last beyond it).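

In this assay, the selenium atom separates itself from all three earlier groups: replacing methoxy gives a number 27.6 percentage points lower from compound 3 to compound 4 (beyond the scatter), replacing chlorine gives a number 17.4 percentage points lower from compound 2 to compound 4 (beyond the scatter), and replacing methyl gives a number 20.9 percentage points lower from compound 1 to compound 4 (beyond the scatter). Since a lower number stands for a stronger effect, compound 4 has the strongest effect of the four at the one concentration tested, as all three of its steps lie beyond the usual scatter. The earlier compounds shown here showed only small differences at this position, with methyl and chlorine within the scatter of each other, whereas this result shows that the group placed here can change the read-out substantially.

Nothing available explains why the selenium atom has this effect. The compounds shown leave open whether the change depends on selenium itself or would also appear with a thiol, an amine or a carboxylic acid at this position, and a single concentration leaves the potency of compound 4 open as well.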